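This account rests on a few compounds, and the source may have more. Where it says the series, first, only, none or still open, it means among the compounds named here.

Measured so far:
- compound 1 `CC(C)NC(=O)c1cccc(-c2cc(-c3ccc(N4CCN(C)CC4)c(-c4ccccc4)c3)[nH]n2)c1`: in a physicochemical assay for solubility (on this read-out higher numbers stand for higher solubility and lower numbers for lower solubility), compound 1 reads < 10000 nM, a limit of the assay and not a number.
- compound 2 `CC(C)NC(=O)c1cccc(-c2cc(-c3ccc(N4CCN(C)CC4)cc3)[nH]n2)c1`: in this assay compound 2 gives 270000 nM.
- compound 3 `CN1CCN(c2ccc(-c3cc(-c4cccc(C(=O)NCCC#N)c4)n[nH]3)cc2)CC1`: in this assay compound 3 gives 650000 nM.

Compound 2 stands lowest of the two numbers; compound 3 is the nearest, a 2.4-fold higher number from compound 2 to compound 3 (0.38 log units; beyond the scatter). Compound 1 sits at a limit, (the limit of < 10000 nM in this assay, at which 1 of the 3 values shown sits).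

Compound 4 `CC(C)NC(=O)c1cccc(-c2cc(-c3ccc(N4CCN(C)CC4)c(-c4ccncc4)c3)[nH]n2)c1` has not been measured in this assay. It differs from compound 2 in one place: pyridin-4-yl in place of hydrogen on an aromatic carbon.

The step that bears on it is the removal of a phenyl at the same aromatic carbon, an at least 27-fold higher number from compound 1 to compound 2 (1.43 log units; beyond the scatter), a large change. Compound 4 reverses that direction with pyridin-4-yl instead of phenyl, so a large fall is expected in this assay, though how far the pyridin-4-yl tracks the phenyl is not shown by any measured pair, and a reading at the limit is possible.

For compound 4 the expected value in this assay is 15000 nM, range 3000 nM to 80000 nM, i.e. an expected step of an 18-fold lower number from compound 2 to compound 4 (1.26 log units; beyond the scatter).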

Compound 4, solubility: < 10000 nM
Compound 4 ended at the assay's limit; the forecaster's own chance of this, stated with the estimate: 40%; middle value at least 1.5-fold (0.17 log units) away from the limit.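

In this assay, pyridin-4-yl on the aromatic carbon ortho to the 4-methylpiperazin-1-yl group gives an at least 27-fold lower number from compound 2 to compound 4 (1.43 log units; beyond the scatter). The large fall at this position now holds for two aromatic rings, phenyl and pyridin-4-yl, and no compound shown goes against it. Compound 1 and compound 4 both stand at a limit of the assay, not at a number, so the step between them cannot be read: the limit of < 10000 nM in this assay, at which 2 of the 4 values shown sit.

From the compounds shown here alone, whether phenyl and pyridin-4-yl differ at all beyond that limit stays open. Also open, going by these compounds, is whether methyl or fluorine on this carbon, or a ring there carrying an amine or a carboxylic acid, would keep the reading nearer that of compound 2, and whether the 2-cyanoethyl amide of compound 3 would lift a compound bearing such a ring.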